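This account rests on a few compounds, and the source may have more. Where it says the series, first, only, none or still open, it means among the compounds named here.

Measured in an ADME assay on HEK293 cells (Homo sapiens) for cytotoxicity, read by luminescence, with a stated time of 72 h (a lower number here means that less compound is needed, a higher number that more compound is needed for the effect), each value a limit:
Compound 1 `CCOC(=O)c1c(-c2cccc(C)c2)[nH]c2cc(OC)ccc2c1=O`: > 22000 nM
Compound 2 `CCOC(=O)c1c(-c2cccc(Cl)c2)[nH]c2cc(OC)ccc2c1=O`: > 22000 nM
Compound 3 `CCOC(=O)c1c(-c2cccc(Br)c2)[nH]c2cc(OC)ccc2c1=O`: > 22000 nM

Compound 3 therefore stands at a limit and not at a number, as do the other two compounds: the limit of > 22000 nM in this assay, at which 3 of the 3 values shown sit. Compound 4 `CCOC(=O)c1c(-c2cccc(Br)c2)[nH]c2cc(OC)c(F)cc2c1=O` differs from compound 3 by one change, (fluoro in place of hydrogen on an aromatic carbon), with fluoro in place of hydrogen on an aromatic carbon, ortho to a methoxy group. Neither a step that the two limits leave unreadable from compound 1 to compound 3 nor a step that the two limits leave unreadable from compound 2 to compound 3 replaces hydrogen with fluoro, and neither has a readable size, so no step beyond the usual scatter is expected in this assay. The expected step is a step that the limit leaves unreadable from compound 3 to compound 4. For compound 4 the estimate is 25000 nM, with an expected range of 12000 nM to 50000 nM.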

Compound 4, half-maximal effective concentration: > 22000 nM
Compound 4: no number, only a limit; the forecaster's own chance of this, stated with the estimate: 85%; the middle value is on the limit's open side.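

For the compounds shown here, compound 3 and compound 4 each stand only at a limit, so no step between them can be read. The compounds shown leave open what concentration any of them needs for the effect in this assay, since all rest on one limit: the limit of > 22000 nM in this assay, at which 4 of the 4 values shown sit.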